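Two Nucleoside Analogues and an Untested Third

The source may hold more compounds than are shown below. What is called first, only, known or untested is meant among the compounds shown, and "the series" means these compounds.

Compound 1 `OC[C@H]1O[C@@H](n2cnc3c(NCc4ccc(Cl)c(Cl)c4)ncnc32)[C@H](O)[C@@H]1O`: > 166000 nM
Compound 2 `OC[C@H]1O[C@@H](n2cnc3c(NCc4cc(F)cc(F)c4)ncnc32)C(O)C1O`: "not determined" (no result reported)

Two compounds with a shared core have been taken into a functional assay on HOS cells (Homo sapiens) for antiproliferative activity, with a stated time of 72 h; a higher number here means a weaker inhibitor, a lower number a stronger inhibitor. For compound 1 the read-out is only a limit of the test and not a number: in this assay compound 1 gives > 166000 nM. For compound 2 this assay records "not determined" (no result reported), so no number exists for it. Compound 1 therefore stands at the limit (the limit of > 166000 nM in this assay, at which 1 of the 2 values shown sits), and the only other entry carries no value at all.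

Compound 3 `OC[C@H]1O[C@@H](n2cnc3c(NCc4ccccc4OC(F)F)ncnc32)[C@H](O)[C@@H]1O` differs from compound 1 in a single place: 2-(difluoromethoxy)phenyl in place of 3,4-dichlorophenyl on a saturated chain carbon bound to a nitrogen on an aromatic ring. Going by the values given here, no pair of measured compounds shows how such a change moves this assay, so the size of the step has no measured footing. The expected step from compound 1 to compound 3 is an at least 1.1-fold lower number from compound 1 to compound 3 (0.04 log units; that floor lies within the scatter), which amounts to no shift beyond the scatter. Compound 3 is estimated at 150000 nM, within a range from 30000 nM to 500000 nM, and a result reported again only as a limit is the more likely outcome.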

Compound 3, half-maximal inhibitory concentration: > 166000 nM
Compound 3 was reported as a limit; the forecaster's own chance of this, stated with the estimate: 70%; middle value at least 1.1-fold (0.04 log units) away from the limit.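

In this assay compound 1 and compound 3 are each reported only as a limit and not as a number, and the step between them cannot be read: the limit of > 166000 nM in this assay, at which 2 of the 3 values shown sit.

The compounds shown leave open whether any group at this place on the shared core would give an actual number in this assay.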